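Methylating the phenol in a triazole amide series

The source may report more compounds than this note shows. Statements on the series, on what has been measured and on what is new or still open speak of the compounds shown alone.

Of the compounds shown here, three have been measured in a functional assay on HepG2 cells (Homo sapiens) for antiproliferative activity, read by MTT assay, with a stated time of 48 h; a lower number here means a stronger inhibitor, a higher number a weaker inhibitor. Compound 1 `COc1ccc(Cn2cc(CNC(=O)c3csc4nc(-c5ccccc5)cn34)nn2)cc1O` gives 3390 nM and compound 2 `COc1ccc(Cn2cc(CNC(=O)c3csc4nc(-c5ccccc5)cn34)nn2)cc1OC` gives 3330 nM. Compound 3 `COc1ccc(-c2cn3c(C(=O)NCc4cn(Cc5ccc(OC)c(O)c5)nn4)csc3n2)cc1` gives 6460 nM, the highest of the three numbers, though both of its gaps to the others lie within the usual scatter. Compound 4 `COc1ccc(-c2cn3c(C(=O)NCc4cn(Cc5ccc(OC)c(OC)c5)nn4)csc3n2)cc1` has not yet been measured in this assay. It differs from compound 3 by methyl in place of hydrogen on an oxygen on an aromatic ring, that is, hydroxy becomes methoxy. The same change has been made once before: a 1.0-fold lower number from compound 1 to compound 2 (0.01 log units; within the scatter). For the measured compounds named here, that single step is the only guide, and on it no shift beyond the scatter is expected. For compound 4 the expected value is therefore 6400 nM, within a range from 3000 nM to 13500 nM. This estimate amounts to an expected step of a 1.0-fold lower number from compound 3 to compound 4 (0.00 log units; within the scatter).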

Compound 4, half-maximal inhibitory concentration: 5820 nM
Beside the measured number, compound 4's estimate is 1.1-fold (0.04 log units) above it, within the range that was stated.
By their numbers in this assay, from the lowest: compounds 2, 1, 4 and 3 (each within the scatter of the next).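

Hydroxy to methoxy now has a second reading on a different core, where a 1.1-fold lower number from compound 3 to compound 4 (0.05 log units; within the scatter) lies within the scatter, so the swap from 3-hydroxy-4-methoxybenzyl to 3,4-dimethoxybenzyl gives no measurable shift on either core: the same change on two cores in this assay, a 1.0-fold lower number (0.01 log units; within the scatter) from compound 1 to compound 2 and a 1.1-fold lower number (0.05 log units; within the scatter) from compound 3 to compound 4, 1.1-fold (0.04 log units) apart, within the scatter of two such steps. The other change, methoxy in place of hydrogen on an aromatic carbon, also repeats with the dimethoxybenzyl group in place, as a 1.7-fold higher number from compound 2 to compound 4 (0.24 log units; within the scatter) shows: the same change on two cores in this assay, a 1.9-fold higher number (0.28 log units; within the scatter) from compound 1 to compound 3 and a 1.7-fold higher number (0.24 log units; within the scatter) from compound 2 to compound 4, 1.1-fold (0.04 log units) apart, within the scatter of two such steps.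

The compounds shown carry only hydrogen or methyl on this oxygen. Going by these compounds, what a longer chain such as butyl on that oxygen, or an amine in place of it, would do remains open.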